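Amide-aryl variation on a fused furyl-triazole thioacetamide series

The source may report more compounds than this note shows. Statements on the series, on what has been measured and on what is new or still open speak of the compounds shown alone.

Measured so far in a functional assay on CHO cells for antagonist activity at Orexin receptor type 2 (Homo sapiens), read by FLIPR and calcium flux; a higher number here means a weaker inhibitor, a lower number a stronger inhibitor:
compound 1 `Cc1cccc(C)c1NC(=O)CSc1nnc(-c2ccoc2C)n1Cc1ccco1` gives > 15800 nM, a limit of the assay.
compound 2 `Cc1occc1-c1nnc(SCC(=O)Nc2ccc(F)cc2)n1Cc1ccco1` gives 158 nM.
compound 3 `Cc1occc1-c1nnc(SCC(=O)Nc2cccc(F)c2)n1Cc1ccco1` gives 501 nM.

Compound 3 holds the higher of the two numbers that are numbers, with compound 2 nearest: a 3.2-fold higher number from compound 2 to compound 3 (0.50 log units; beyond the scatter). Compound 1 stands apart at the limit (the limit of > 15800 nM in this assay, at which 1 of the 3 values shown sits).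

The next compound is compound 4 `COc1ccccc1NC(=O)CSc1nnc(-c2ccoc2C)n1Cc1ccco1`. Its change from compound 3 is 2-methoxyphenyl in place of 3-fluorophenyl on an amide-type nitrogen. Every measured step in this set moves the same amide-type nitrogen substituent. Two of them are large: an at least 100-fold lower number from compound 1 to compound 2 (2.00 log units; beyond the scatter) and an at least 31-fold lower number from compound 1 to compound 3 (1.49 log units; beyond the scatter), both going from 2,6-dimethylphenyl to a fluorophenyl. The third is modest: a 3.2-fold higher number from compound 2 to compound 3 (0.50 log units; beyond the scatter), a move of one fluorine. The step to compound 4 exchanges fluorine for methoxy and changes its numbered place, so it is larger than the modest 2>3 step but smaller than a swap back to 2,6-dimethylphenyl. A rise in this assay is expected for compound 4, of a size a 5.0-fold higher number from compound 3 to compound 4 (0.70 log units; beyond the scatter), with the limit a real possibility given compound 1 at the limit of > 15800 nM in this assay, at which 1 of the 3 values shown sits. The number expected for compound 4 is 2500 nM, within 500 nM to 12000 nM.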

Compound 4, inhibition constant: 501 nM
Compound 4: the middle estimate sits 5.0-fold (0.70 log units) above what was measured, and the stated range covers the measured number.
By their numbers in this assay, from the lowest: compound 2; then compounds 3 and 4 (each within the scatter of the next). At a limit, above all of these: compound 1.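

In this assay, exchanging 3-fluorophenyl for 2-methoxyphenyl on the amide-type nitrogen gives no change at the digits printed from compound 3 to compound 4 (within the scatter), so a change of both the substituent and its numbered place leaves no readable difference between these two groups. The series also shows an at least 31-fold lower number from compound 1 to compound 4 (1.49 log units; beyond the scatter), so 2-methoxyphenyl does not reproduce the loss seen with 2,6-dimethylphenyl, although this step starts from a limit and not a number: the limit of > 15800 nM in this assay, at which 1 of the 4 values shown sits.
Against 4-fluorophenyl the result is a 3.2-fold higher number from compound 2 to compound 4 (0.50 log units; beyond the scatter), which leaves 4-fluorophenyl with the lowest number among the four amide aryl groups.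

As far as these compounds go, it remains open whether fluorine and methoxy would also match at one shared place, as a pair such as 2-fluorophenyl and 4-methoxyphenyl set against the groups already in hand would show, and whether a single methyl, as in 2-methylphenyl, is enough to reach the limit. Also open, from the compounds shown here alone, is whether the amide-type nitrogen needs an aryl group at all, for which a cyclohexyl group or a longer alkyl chain in place of the aromatic ring would be the test.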